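From 4-fluorophenyl to 4-ethoxyphenyl in the series

The source may hold more compounds than are shown below. What is called first, only, known or untested is meant among the compounds shown, and "the series" means these compounds.

In a functional assay on FM3A cells (Mus musculus) for antiproliferative activity (on this read-out lower numbers stand for stronger inhibition and higher numbers for weaker inhibition), compound 3 (`COc1cc(C(=O)c2sc(-c3ccc(F)cc3)cc2N)cc(OC)c1OC`) gives 16 nM, the middle of three numbers. Compound 1 (`COc1cc(C(=O)c2sc(-c3ccc([N+](=O)[O-])cc3)cc2N)cc(OC)c1OC`) gives 64 nM, and compound 2 (`COc1cc(C(=O)c2sc(-c3ccsc3)cc2N)cc(OC)c1OC`) gives 3.7 nM.

Compound 4 (`CCOc1ccc(-c2cc(N)c(C(=O)c3cc(OC)c(OC)c(OC)c3)s2)cc1`) has ethoxy in place of fluoro on an aromatic carbon, para to a large group: ethoxy in place of fluoro on an aromatic carbon. At that place, fluoro in place of nitro gave a 4.0-fold lower number from compound 1 to compound 3 (0.60 log units; beyond the scatter), a modest step. Exchange of thiophen-3-yl for 4-fluorophenyl gave a 4.3-fold higher number from compound 2 to compound 3 (0.64 log units; beyond the scatter), also modest. The large step, a 17-fold lower number from compound 1 to compound 2 (1.24 log units; beyond the scatter), starts from the nitro compound. Going by the values given here, no measured compound carries ethoxy, so the direction is uncertain, and no step beyond the scatter is expected in this assay. The expected step is a 1.3-fold lower number from compound 3 to compound 4 (0.12 log units; within the scatter). Compound 4 is estimated at 12 nM, with an expected range of 3.5 nM to 45 nM.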

Compound 4, half-maximal inhibitory concentration: 510 nM
Compound 4: middle estimate off by 43-fold (1.63 log units), on the low side; the measured number lies above the stated range.
By their numbers in this assay, from the lowest: compound 2; then compound 3; then compound 1; then compound 4.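

Ethoxy in place of fluoro on this aromatic carbon is a far larger penalty than any earlier change at this place (a 32-fold higher number from compound 3 to compound 4 (1.50 log units; beyond the scatter)). Compound 4 now has the highest number of the four, beyond the nitro compound (an 8.0-fold higher number from compound 1 to compound 4 (0.90 log units; beyond the scatter)) and far beyond the thiophen-3-yl compound (a 140-fold higher number from compound 2 to compound 4 (2.14 log units; beyond the scatter)). Nothing available here explains this loss.

Going by these compounds, whether the attached oxygen or the two-carbon chain behind it carries the penalty stays open. Methoxy, hydroxy and a longer chain such as propoxy at this place would separate the two.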